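Fluoro to Methoxy on a Shared Core: Expecting Another Limit

The source may report more compounds than this note shows. Statements on the series, on what has been measured and on what is new or still open speak of the compounds shown alone.

Measured so far:
Compound 1, `CN(C)CCNc1ccnc2cc(Cl)ccc12`, gives > 20000 nM in a functional assay on 184B5 cells (Homo sapiens) for cytotoxicity, read by sulforhodamine B assay, with a stated time of 48 h, in the presence of a further agent that is not named here; on this read-out lower numbers stand for stronger inhibition of growth and higher numbers for weaker inhibition of growth.
Compound 2, `CN(C)CCNc1ccnc2cc(F)ccc12`, gives > 20000 nM in this assay.

Compound 2 stands at the edge of what this assay can report: its value is a limit of the assay, not a number. Within the data shown here, the only measured step, a step that the two limits leave unreadable from compound 1 to compound 2, cannot be read in size or direction since both values sit at the limit (the limit of > 20000 nM in this assay, at which 2 of the 2 values shown sit).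

Compound 3, `COc1ccc2c(NCCN(C)C)ccnc2c1`, differs from compound 2 by methoxy in place of fluoro on an aromatic carbon. Among the measured compounds shown here, no measured step bears on this change, so there is no ground to expect movement in this assay beyond the scatter, in either direction. The estimated step is a step that the limit leaves unreadable from compound 2 to compound 3. Compound 3 is therefore expected to give around 30000 nM, between 10000 nM and 100000 nM, and most likely the assay will again report only a limit.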

Compound 3, concentration for 50% growth inhibition: > 20000 nM
Compound 3: a limit, no number (the forecaster's own chance of this, stated with the estimate: 80%); the middle value lies beyond the limit too.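

Compound 3 also gives only a limit of the assay, so no step among compound 1, compound 2 and compound 3 can be read in size or direction: the limit of > 20000 nM in this assay, at which 3 of the 3 values shown sit.

On these data alone, how strongly these three compounds inhibit growth, and whether exchanging chloro, fluoro and methoxy on the shared core makes any difference, remains open.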